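Chloro to Methyl on the Anilide Ring at Two Positions

The source may hold more compounds than are shown below. What is called first, only, known or untested is meant among the compounds shown, and "the series" means these compounds.

Compound 1 `N#Cc1cc(F)cc(C(=O)Nc2ccccc2Cl)c1` and compound 3 `Cc1ccccc1NC(=O)c1cc(F)cc(C#N)c1` share one core, while compound 2 `N#Cc1cc(F)cc(C(=O)Nc2cccc(Cl)c2)c1` is built from the same atoms joined differently; the difference between the two cores is not broken down here. In an in vitro functional assay on HEK293-A cells for antagonist activity at metabotropic glutamate receptor 5 (Rattus norvegicus), read by calcium flux (a lower number here means a stronger inhibitor, a higher number a weaker inhibitor), compound 1 reaches only a limit, > 30000 nM. Compound 3 also reaches only a limit, > 30000 nM. Compound 2 gives 45 nM. The change methyl in place of chloro on an aromatic carbon thus yields a step that the two limits leave unreadable from compound 1 to compound 3, owing to the limit of > 30000 nM in this assay, at which 2 of the 3 values shown sit. The same kind of change, (methyl in place of chloro on an aromatic carbon), leads to compound 4 `Cc1cccc(NC(=O)c2cc(F)cc(C#N)c2)c1`, though here the place is meta to a large group rather than ortho to a large group. Resting on the value of compound 2, 45 nM, compound 4 is expected to lie near 150 nM, between 40 nM and 1500 nM. The expected step is a 3.3-fold higher number from compound 2 to compound 4 (0.52 log units; beyond the scatter).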

Compound 4, half-maximal inhibitory concentration: 122 nM
Estimate against measurement, compound 4: 1.2-fold (0.09 log units) above; the measured number falls inside the stated range.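

In this assay, methyl in place of chloro on an aromatic carbon, meta to a large group, gives a 2.7-fold higher number from compound 2 to compound 4 (0.43 log units; beyond the scatter), so compound 4 remains a measurable inhibitor after the change. The same change on the core of compound 1 cannot be read, so no size can be set beside this step: the limit of > 30000 nM in this assay, at which 2 of the 4 values shown sit. The series therefore offers a single readable step, which does not show that the change carries the same size from one core to the other.

The compounds shown leave open how an amine or a methoxy group reads in place of the chloro, meta to a large group. They also leave open whether this step holds when a carboxylic acid replaces the nitrile.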